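This account rests on a few compounds, and the source may have more. Where it says the series, first, only, none or still open, it means among the compounds named here.

Measured in a functional assay on B16-F10 cells (Mus musculus) for inhibition, read by MTT assay, with a stated time of 48 h; on this read-out lower numbers stand for stronger inhibition and higher numbers for weaker inhibition:
compound 1, `CCCCCCCCNC(=O)/C=C/c1c(/C=C/c2ccc(OC)cc2)cc(OC)cc1OC`: 8060 nM
compound 2, `COc1ccc(/C=C/c2cc(OC)cc(OC)c2/C=C/C(=O)N2CCCCC2)cc1`: 9750 nM
compound 3, `COc1ccc(/C=C/c2cc(OC)cc(OC)c2/C=C/C(=O)N2CCCC2)cc1`: 9280 nM

Compound 1 gives the lowest of the three numbers, but its steps to compound 3 and to compound 2 both sit within the scatter, so no order among the three is established. Compound 4, `COc1ccc(/C=C/c2cc(OC)cc(OC)c2/C=C/C(=O)N2CCN(C)CC2)cc1`, is the next point: 4-methylpiperazin-1-yl in place of octylamino on a carbonyl carbon. Within the data shown here, the steps that bear on it are a 1.2-fold higher number from compound 1 to compound 2 (0.08 log units; within the scatter) and a 1.2-fold higher number from compound 1 to compound 3 (0.06 log units; within the scatter), both replacing octylamino with a cyclic amine on the same carbonyl carbon, and neither leaves the scatter. The 4-methylpiperazin-1-yl change is expected to behave likewise, giving a 1.3-fold higher number from compound 1 to compound 4 (0.11 log units; within the scatter), with no step beyond the scatter. Compound 4 is therefore estimated at 10500 nM, range 5000 nM to 22000 nM.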

Compound 4, half-maximal inhibitory concentration: 5670 nM
Compound 4: the middle estimate sits 1.9-fold (0.27 log units) above what was measured, within the range that was stated.
By their numbers in this assay, from the lowest: compounds 4, 1, 3 and 2 (each within the scatter of the next).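

In this assay, 4-methylpiperazin-1-yl on the carbonyl carbon, with its second ring nitrogen, yields no step beyond the scatter (a 1.4-fold lower number from compound 1 to compound 4 (0.15 log units; within the scatter); a 1.6-fold lower number from compound 3 to compound 4 (0.21 log units; within the scatter); a 1.7-fold lower number from compound 2 to compound 4 (0.24 log units; within the scatter)). Exchanging octylamino for this ring removes the hydrogen-bond donor and the open chain, yet compound 4 cannot be ordered against compound 1. No accompanying measurement bears on a cause. Still open, going by these compounds, is whether a carboxylic acid at the end of the octyl chain, or a shorter chain such as ethylamino, would produce a step beyond the scatter.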